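Trading a Polar Side Chain for a Short Alkyl Chain

The source may report more compounds than this note shows. Statements on the series, on what has been measured and on what is new or still open speak of the compounds shown alone.

Compound 1 `CC(=O)NCC[C@@H]1C[C@@H](c2ccc(F)c(F)c2)[C@H](NC(=O)c2cc(-c3c(Cl)cnn3C)c(Cl)o2)CN1`: 2.49 nM
Compound 2 `Cn1ncc(Cl)c1-c1cc(C(=O)N[C@@H]2CN[C@H](CCN3CCC(O)CC3)C[C@H]2c2ccc(Cl)c(Cl)c2)oc1Cl`: 5.99 nM
Compound 3 `Cn1ncc(Cl)c1-c1cc(C(=O)NC2CNCC2c2ccc(C(F)(F)F)cc2)oc1Cl`: 538 nM

All three compounds were tested in an assay for inhibition of RAC-alpha serine/threonine-protein kinase (Homo sapiens), read by HTRF, with a stated time of 1 h; on this read-out higher numbers stand for weaker inhibition and lower numbers for stronger inhibition. Compound 2 stands second highest of the three numbers: compound 1 gives a lower number, a gap beyond the scatter, while compound 3 gives a far higher number, also beyond the scatter. Compound 4 `CCC[C@@H]1C[C@@H](c2ccc(Cl)c(Cl)c2)[C@H](NC(=O)c2cc(-c3c(Cl)cnn3C)c(Cl)o2)CN1` differs from compound 2 in one place: methyl in place of 4-hydroxypiperidin-1-yl on a saturated chain carbon, two bonds along the chain from a saturated ring carbon. Among the measured compounds shown here, no measured pair shows this change directly, so the expected step of a 1.7-fold higher number from compound 2 to compound 4 (0.22 log units; within the scatter) is a modest weakening, around the edge of the scatter, given that compound 1 and compound 2 both carry a longer substituted chain and sit close together. Compound 4 is therefore expected to give 10 nM, within a range of 3 nM to 40 nM.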

Compound 4, half-maximal inhibitory concentration: 10.4 nM
For compound 4 the middle estimate is 1.0-fold (0.02 log units) below the measured one; the range from low to high includes it.
By their numbers in this assay, from the lowest: compound 1; then compounds 2 and 4 (each within the scatter of the next); then compound 3.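

Methyl in place of 4-hydroxypiperidin-1-yl, on a saturated chain carbon, two bonds along the chain from a saturated ring carbon, gives a 1.7-fold higher number from compound 2 to compound 4 (0.24 log units; within the scatter) in this assay. At this position, therefore, the 2-(4-hydroxypiperidin-1-yl)ethyl chain can be cut to plain propyl, losing the ring and every hydrogen-bond donor and acceptor of the group, without moving the number beyond the scatter. Nothing measured here offers a reason for this outcome.

The compounds shown leave open whether a primary amine, a carboxylic acid or a longer alkyl chain such as butyl would fare the same at this place. They also leave open whether propyl would hold on the core of compound 1.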